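Lengthening the ester chain: from compound 2 to compound 3

The source may report more compounds than this note shows. Statements on the series, on what has been measured and on what is new or still open speak of the compounds shown alone.

Measured in a functional assay on A549 cells (Homo sapiens) for inhibition, read by MTT assay; on this read-out higher numbers stand for weaker inhibition and lower numbers for stronger inhibition:
- compound 1 `CCCCCCCCCCCC(=O)OC1=C(CC=C(C)C)C(=O)c2ccccc2C1=O`: 35000 nM
- compound 2 `CCCCCCCCCCCCCC(=O)OC1=C(CC=C(C)C)C(=O)c2ccccc2C1=O`: 49000 nM

Among the measured compounds shown here, only two measured values are available so far. Compound 2, at 49000 nM, lies within the usual scatter of compound 1, at 35000 nM, so the two cannot be ranked.

The next compound to be measured is compound 3 `CCCCCCCCCCCCCCCC(=O)OC1=C(CC=C(C)C)C(=O)c2ccccc2C1=O`. Its difference from compound 2 is ethyl in place of hydrogen on a saturated chain carbon, ten or more bonds along the chain from a carbonyl carbon, which places ethyl in place of hydrogen on a saturated chain carbon, ten or more bonds along the chain from a carbonyl carbon.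

For the measured compounds named here, one measured step bears on this change, since the same replacement gave a 1.4-fold higher number from compound 1 to compound 2 (0.15 log units; within the scatter). That single step stayed within the scatter and does not establish a trend. Any step in this assay is therefore expected to be of similar size, towards a higher number if it shows at all, and not clearly beyond the scatter.

The expected change is a 1.2-fold higher number from compound 2 to compound 3 (0.09 log units; within the scatter). The estimated value for compound 3 is 60000 nM, with an expected range of 35000 nM to 110000 nM.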

Compound 3, half-maximal inhibitory concentration: 38000 nM
For compound 3 the middle estimate is 1.6-fold (0.20 log units) above the measured one; low and high end bracket the measured number.
By their numbers in this assay, from the lowest: compounds 1, 3 and 2 (each within the scatter of the next).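

In this assay the replacement of hydrogen by ethyl on a saturated chain carbon now gives a 1.3-fold lower number from compound 2 to compound 3 (0.11 log units; within the scatter) and the earlier step was a 1.4-fold higher number from compound 1 to compound 2 (0.15 log units; within the scatter) so the two steps do not share a direction and neither stands out from the scatter. Over the whole span, butyl in place of hydrogen at this place gives a 1.1-fold higher number from compound 1 to compound 3 (0.04 log units; within the scatter) and this wider change is also within the scatter, so compound 1, compound 2 and compound 3 cannot be ranked and no dependence on chain length can be read from them. No measurement on hand explains this result.

Still open, on these data alone, is whether the insensitivity holds beyond this narrow range of long chains, for example with a much shorter chain such as butyl in place of the whole ester chain, or with a much longer chain. Also open, as far as these compounds go, is how the series would respond to a chain carrying an amine or a carboxylic acid, or to an amide in place of the ester.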